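The source may report more compounds than this note shows. Statements on the series, on what has been measured and on what is new or still open speak of the compounds shown alone.

Measured in a functional assay on NCI-H460 cells (Homo sapiens) for antiproliferative activity, with a stated time of 72 h; a higher number here means a weaker inhibitor, a lower number a stronger inhibitor:
Compound 1 `CCCCC#Cc1cc([C@@H]2O[C@H](CO)[C@@H](O)[C@H]2O)n2ncnc(N)c12` gives 1700 nM.
Compound 2 `Nc1ncnn2c([C@@H]3O[C@H](CO)[C@@H](O)[C@H]3O)cc(-c3ccc(Cl)cc3)c12` gives 45900 nM.

Compound 2 stands highest of the two numbers, separated from compound 1 by a 27-fold higher number from compound 1 to compound 2 (1.43 log units; beyond the scatter). Compound 3 `Cc1ccccc1-c1cc([C@@H]2O[C@H](CO)[C@@H](O)[C@H]2O)n2ncnc(N)c12` differs from compound 2 by 2-methylphenyl in place of 4-chlorophenyl on an aromatic carbon. Among the compounds with values here, no measured step exchanges one six-membered aromatic ring of carbon only for another; the single known step replaces a chain with such a ring, so it gives little guidance for this exchange. Therefore no change beyond the scatter is expected, though with wide uncertainty. Compound 3 is estimated at 40000 nM in this assay, within 10000 nM to 150000 nM, which means an expected step of a 1.1-fold lower number from compound 2 to compound 3 (0.06 log units; within the scatter).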

Compound 3, half-maximal inhibitory concentration: > 100000 nM
Compound 3: a limit, no number (the forecaster's own chance of this, stated with the estimate: 15%); middle value at least 2.5-fold (0.39 log units) away from the limit.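

In this assay compound 3 carries a limit of the assay and not a number: the limit of > 100000 nM in this assay, at which 1 of the 3 values shown sits.

Even so, exchanging 4-chlorophenyl for 2-methylphenyl on this aromatic carbon is not neutral, with an at least 2.1-fold higher number from compound 2 to compound 3 (0.33 log units; beyond the scatter), so one six-membered aromatic ring of carbon only cannot simply stand in for another here. The hex-1-yn-1-yl chain also keeps its lead over this new ring, with an at least 58-fold higher number from compound 1 to compound 3 (1.76 log units; beyond the scatter).

Still open, from the compounds shown here alone, is whether the methyl group itself or its place on the ring drives the step, and how a longer alkyne chain or an amine on this carbon would compare.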